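A few compounds are considered here, and "the series" means these few. Any claim that something is new, unique, unknown or untested is made for them only; others in the source may bear on it.

Compound 2 `O=C(CCCc1ccccc1)Nc1nc2ccccc2c(=O)s1` is the anchor of this short series. In an assay on mitochondria (strain Sprague-Dawley) for inhibition of Amine oxidase [flavin-containing] B (Rattus norvegicus), read by fluorescence and Amplex Red, with stated times of 30 min and 45 min (a lower number here means a stronger inhibitor, a higher number a weaker inhibitor), compound 2 gives 186 nM, the lowest of the two plain numbers shown; the nearest is compound 1 `COc1cccc(CCCC(=O)Nc2nc3ccccc3c(=O)s2)c1`, which in this assay gives 1300 nM, so that the step of a 7.0-fold lower number from compound 1 to compound 2 (0.84 log units; beyond the scatter) is a modest gain. Compound 3 `O=C(CCCc1ccccc1)Nc1nc2ccc(Cl)cc2c(=O)s1` gives in this assay only a limit, > 10000 nM, which is the limit of > 10000 nM in this assay, at which 1 of the 3 values shown sits. The step of an at least 53-fold higher number from compound 2 to compound 3 (1.73 log units; beyond the scatter) is therefore a large loss.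

Compound 4 `O=C(CCc1ccccc1Br)Nc1nc2ccccc2c(=O)s1` has not yet been measured. Against compound 2 the change is 2-bromophenyl in place of benzyl on a saturated chain carbon, two bonds along the chain from a carbonyl carbon. Neither measured step touches this position directly: the step from compound 1 to compound 2 concerns a methoxy on the distal aromatic ring, and the step from compound 2 to compound 3 a chloro on the shared core. Both, however, show that a substituent added to an aromatic ring of compound 2 raises the number, by a modest and by a large amount. A bromine on the distal ring, with the chain shortened, is therefore expected to cost something in this assay, estimated at a 3.2-fold higher number from compound 2 to compound 4 (0.51 log units; beyond the scatter), beyond the scatter but well short of the limit. For compound 4 the expected value in this assay is 600 nM, with a range of 150 nM to 3000 nM.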

Compound 4, half-maximal inhibitory concentration: 64 nM
The estimate for compound 4 lay 9.4-fold (0.97 log units) above the measured number; measured number outside the range, below it.
By their numbers in this assay, from the lowest: compound 4; then compound 2; then compound 1. At a limit, above all of these: compound 3.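

In this assay, the step of a 2.9-fold lower number from compound 2 to compound 4 (0.46 log units; beyond the scatter) shows that the distal end of the chain accepts a change without loss: 2-bromophenyl in place of benzyl, on a saturated chain carbon, two bonds along the chain from a carbonyl carbon, lowers the number. Until now, the only substituents shown on an aromatic ring of this series, the methoxy of compound 1 and the chloro of compound 3, came with higher numbers than compound 2, and compound 4 goes against any rule that a ring substituent costs activity in this series. The result also shows that the distal ring tolerates a halogen in a way the core of compound 3 does not, although the two sites differ and the chain differs too, and no measured property shown here accounts for the step.

The single step carries two changes at once, a shorter chain and a bromine, and the compounds shown do not divide the gain between them. A plain phenyl on the shorter chain, a chloro or methoxy in place of the bromine, a longer chain bearing 2-bromophenyl, or an amine on the distal ring would each help to separate the two.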